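The source may report more compounds than this note shows. Statements on the series, on what has been measured and on what is new or still open speak of the compounds shown alone.

Measured compounds:
Compound 1, `O=C(O)c1csc([C@H]2CC[C@@H]3[C@@H](COc4ccc(C(F)(F)F)cc4)[C@H](O)C[C@@H]3O2)n1`, gives 13 nM.
Compound 2, `O=C(O)c1csc([C@H]2CC[C@@H]3[C@@H](/C=C/CCCOc4ccccc4)[C@H](O)C[C@@H]3O2)n1`, gives 13 nM.

Both were tested in a functional assay on CHO cells for agonist activity at prostaglandin E2 receptor EP2 subtype (Homo sapiens), read by HTRF and cAMP accumulation, with a stated time of 30 min; a lower number here means that less compound is needed, a higher number that more compound is needed for the effect. Compound 1 stands level with compound 2 at the digits reported; the two values lie within the scatter of each other, so no order between them can be read from the numbers. The two compounds share a core and differ in the side chain on the oxygen attached to a saturated carbon, and that difference leaves the read-out unchanged within the scatter.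

Compound 3, `O=C(O)c1csc([C@H]2CC[C@@H]3[C@@H](COc4cccc(Cl)c4)[C@H](O)C[C@@H]3O2)n1`, has not yet been measured. It differs from compound 1 in one place: 3-chlorophenyl in place of 4-(trifluoromethyl)phenyl on an oxygen on a saturated carbon. Going by the values given here, no measured pair shows this particular exchange, so the size of its effect is not known from the data. Given that the two measured compounds carry quite different groups at this oxygen and still compound 1 reads 13 nM while compound 2 reads 13 nM, a change of aryl group here is expected to stay within the scatter or shift the value only a little.

The step from compound 1 to compound 3 is estimated at a 1.5-fold higher number from compound 1 to compound 3 (0.19 log units; within the scatter). Compound 3 is expected to give 20 nM, with a range from 7 nM to 60 nM.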

Compound 3, half-maximal effective concentration: 6.5 nM
Estimate against measurement, compound 3: 3.1-fold (0.49 log units) above; the whole stated range lies above it.
By their numbers in this assay, from the lowest: compounds 3, 1 and 2 (each within the scatter of the next).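

In this assay, going by these compounds alone, putting 3-chlorophenyl in place of 4-(trifluoromethyl)phenyl on an oxygen on a saturated carbon gives a 2.0-fold lower number from compound 1 to compound 3 (0.30 log units; within the scatter), the first direct reading of an exchange of one aryl group for another at this place. The earlier compounds shown here offered no such pair, and this one shows that the read-out tolerates this particular exchange, from a group of 10 heavy atoms to one of 7 and from a fluorine-bearing substituent to a chlorine, without a change that can be told from the scatter. The data hold no measurement that could say why the two aryl groups read alike, so the result stands as an observation only.

The compounds shown leave open how a plain phenyl ring, a pyridine ring or a cyclohexyl group on the same oxygen would read, and so whether any aryl group at this place moves the number beyond the scatter. They also leave open how the shared core would read with an amide in place of its carboxylic acid, since that acid is common to every compound here.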